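This account rests on a few compounds, and the source may have more. Where it says the series, first, only, none or still open, it means among the compounds named here.

Compound 2 `Cc1nc(N)c2c(I)cn([C@@H]3O[C@H](CO)[C@@H](O)[C@H]3O)c2n1` gives 24600 nM in an ADME assay on BJ cells (Homo sapiens), read by MTT assay, with a stated time of 72 h; a lower number here means a stronger inhibitor, a higher number a weaker inhibitor. Compound 1 `Cc1nc(N)c2c(-c3ccccc3)cn([C@@H]3O[C@H](CO)[C@@H](O)[C@H]3O)c2n1` returns only a limit in this assay, > 100000 nM. The change from compound 2 to compound 1 is phenyl in place of iodo on an aromatic carbon, and it brings an at least 4.0-fold higher number from compound 2 to compound 1 (0.60 log units; beyond the scatter). Compound 3 `CNc1ncnc2c1c(I)cn2[C@@H]1O[C@H](CO)[C@@H](O)[C@H]1O` likewise yields only a limit in this assay, > 100000 nM. How the core of compound 3 differs from the core of compound 2 is not broken down here. Compound 4 `CNc1ncnc2c1c(-c1ccccc1)cn2[C@@H]1O[C@H](CO)[C@@H](O)[C@H]1O` has not been measured; it differs from compound 3 by phenyl in place of iodo on an aromatic carbon, the same change as that from compound 2 to compound 1. Compound 3 already stands at the limit of > 100000 nM in this assay, at which 2 of the 3 values shown sit. The earlier change produced an at least 4.0-fold higher number from compound 2 to compound 1 (0.60 log units; beyond the scatter). On that basis compound 4 is expected to stay at a limit, with an estimated step that the limit leaves unreadable from compound 3 to compound 4. Compound 4 is estimated at 300000 nM in this assay, somewhere between 100000 nM and 1000000 nM.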

Compound 4, half-maximal inhibitory concentration: > 100000 nM
Compound 4 gave a limit, no number; the forecaster's own chance of this, stated with the estimate: 95%; the middle value lies beyond the limit too.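

Compound 3 and compound 4 each give only a limit in this assay, so the step between them cannot be read. The compounds shown leave open whether phenyl in place of iodo changes the number on the core of compound 3.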